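The source may hold more compounds than are shown below. What is called first, only, known or untested is meant among the compounds shown, and "the series" means these compounds.

Measured compounds:
Compound 1, `O=C1O/C(=C\Cn2cc(-c3ccc(Br)cc3)nn2)C(OCc2ccccc2)=C1OCc1ccccc1`, in a functional assay on A549 cells (Homo sapiens) for antiproliferative activity, read by MTT assay, with a stated time of 72 h; on this read-out lower numbers stand for stronger inhibition and higher numbers for weaker inhibition: > 100000 nM, a limit of the assay.
Compound 2, `O=C1O/C(=C\Cn2cc(-c3cc(F)cc(F)c3)nn2)C(OCc2ccccc2)=C1OCc1ccccc1`, in this assay: > 100000 nM, again a limit of the assay.
Compound 3, `O=C1O[C@H]([C@@H](O)Cn2cc(-c3cccc(O)c3)nn2)C(OCc2ccccc2)=C1OCc1ccccc1`, in this assay: 59900 nM.

Compound 3 is the only one of the three with a number rather than a limit in this assay. Compounds 1 and 2 both sit at the limit of > 100000 nM in this assay, at which 2 of the 3 values shown sit, and the step that the two limits leave unreadable from compound 1 to compound 2 therefore cannot be read. Within the data shown here, there is thus no measured step that shows how a change on the triazole substituent moves the read-out.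

Compound 4, `O=C1O[C@H]([C@@H](O)Cn2cc(CCO)nn2)C(OCc2ccccc2)=C1OCc1ccccc1`, differs from compound 3 in one place: 2-hydroxyethyl in place of 3-hydroxyphenyl on an aromatic carbon. The 3-hydroxyphenyl group leaves and a 2-hydroxyethyl group enters, the rest of the molecule, including the hydroxyl-bearing ring carbon and the two benzyloxy groups, being unchanged. Among the measured compounds shown here, none of the measured steps bears on this exchange, so no direction can be taken from them.

The account therefore expects compound 4 to stay within the scatter of compound 3, which it states as a step of a 1.3-fold higher number from compound 3 to compound 4 (0.13 log units; within the scatter). Compound 4 is estimated at 80000 nM, between 30000 nM and 200000 nM, with a real chance that the assay returns only its limit.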

Compound 4, half-maximal inhibitory concentration: > 100000 nM
Compound 4 gave a limit, no number (the forecaster's own chance of this, stated with the estimate: 40%); at least 1.2-fold (0.09 log units) between middle value and limit.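

Among these compounds, with this result a change at this position can be read for the first time, if only in part: in this assay, 2-hydroxyethyl in place of 3-hydroxyphenyl, on the aromatic carbon of the five-membered aromatic ring with 3 nitrogen, gives an at least 1.6-fold higher number from compound 3 to compound 4 (0.22 log units; that floor lies within the scatter). Among the compounds shown here, that floor lies within the scatter, so the pair does not establish a real loss; it shows only that this exchange, which removes the six-membered aromatic ring and keeps one hydrogen-bond donor and one acceptor, brings no measurable gain over compound 3. Compound 4 gives a limit of the assay, not a number, and it stands there with compound 1 and compound 2: the limit of > 100000 nM in this assay, at which 3 of the 4 values shown sit.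

How far the true value of compound 4 lies from that of compound 3 remains open, and the step from compound 1 to compound 2 cannot be read, so the compounds shown give no order among the groups at this position. Also open, as far as these compounds go, is whether an amine, a carboxylic acid or a longer chain in place of 2-hydroxyethyl would give a number rather than a limit.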